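A few compounds are considered here, and "the series" means these few. Any claim that something is new, unique, unknown or untested is made for them only; others in the source may bear on it.

Measured so far:
Compound 1, `N=C(NCCCc1c[nH]cn1)NCCC(c1ccc(Br)cc1)c1ccccn1`: 120 nM
Compound 2, `N=C(NCCCc1c[nH]cn1)NCCC(c1cccc(F)c1)c1ccccn1`: 158 nM

Both compounds were tested in a functional assay on ileum for antagonist activity at histamine H1 receptor (Cavia porcellus); a higher number here means weaker binding, a lower number tighter binding. There compound 1 gives 120 nM, and compound 2 gives 158 nM. The two numbers are not separated: the step of a 1.3-fold higher number from compound 1 to compound 2 (0.12 log units; within the scatter) lies within the scatter, so compound 2 cannot be told apart from compound 1 on these data, even though its number is the larger of the two.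

Compound 3, `N=C(NCCCc1c[nH]cn1)NCCC(c1cc(F)cc(F)c1)c1ccccn1`, is not yet measured. Relative to compound 2 the change is fluoro in place of hydrogen on an aromatic carbon. Going by the values given here, the only measured step that bears on it is the one on the same ring, a 1.3-fold higher number from compound 1 to compound 2 (0.12 log units; within the scatter), in which one halogenated phenyl replaced another without a change beyond the scatter. Among the compounds with values here, the single step from compound 2 to compound 3 adds a second fluoro to that ring, and with one comparable step showing no movement, nothing in these data points to a shift in either direction. Compound 3 is therefore expected to stay close to compound 2, with an estimated step of a 1.0-fold higher number from compound 2 to compound 3 (0.01 log units; within the scatter). The estimate for compound 3 in this assay is 160 nM, within a range from 70 nM to 350 nM.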

Compound 3, dissociation constant: 275 nM
Compound 3: middle estimate off by 1.7-fold (0.24 log units), on the low side, within the range that was stated.
By their numbers in this assay, from the lowest: compounds 1, 2 and 3 (each within the scatter of the next, the first and the last beyond it).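

In this assay, the second fluoro, placed meta to a fluoro group on the six-membered aromatic ring, gives a 1.7-fold higher number from compound 2 to compound 3 (0.24 log units; within the scatter), so this one addition cannot be told apart from leaving the hydrogen in place. Going by these compounds alone, the wider exchange, 3,5-difluorophenyl in place of 4-bromophenyl, gives a 2.3-fold higher number from compound 1 to compound 3 (0.36 log units; beyond the scatter), the first step here to pass the scatter, although modestly, which shows that the substitution on this ring can register in the assay even though neither of the two smaller steps through compound 2 does so on its own. Nothing available accounts for this difference, and the three compounds alone offer no explanation of it.

The compounds shown leave open whether a further group on this ring, such as a methoxy, a trifluoromethyl or an amine, would move the number clearly in either direction. They also leave open how a longer chain in the shared core would behave, and whether the modest separation of these two halogenated phenyl compounds would persist with a different group on the ring.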